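A few compounds are considered here, and "the series" means these few. Any claim that something is new, unique, unknown or untested is made for them only; others in the source may bear on it.

Working notes on the series. The read-out throughout is an ADME assay on K562 cells (Homo sapiens) for cytotoxicity, read by luminescence and ATP content, with a stated time of 48 h; a lower number here means a stronger inhibitor, a higher number a weaker inhibitor. Among the measured compounds shown here, compound 1 `O=C1OCC(c2ccc(C(F)(F)F)cc2)=C1c1c[nH]c2ccccc12` gives 260 nM in this assay and is the only member with a finite number. Compound 2 `O=C1OCC(c2ccc(C(F)(F)F)cc2)=C1c1ccncc1` returns > 40000 nM in this assay, which is a limit of the assay and not a measured number. Compound 3 `COc1ccc(C2=C(c3ccc(OC)c(OC)c3)C(CO)OC2=O)cc1` likewise returns > 40000 nM in this assay, again a limit rather than a number. Where compound 3 stands is therefore only partly known: it sits at the limit of > 40000 nM in this assay, at which 2 of the 3 values shown sit, and no step between measured compounds that differ in a single place exists in this set, so nothing here calibrates a change of the kind described next.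

Compound 4 `COc1ccc(C2=C(c3ccc(OC)c(OC)c3)C(CO)(CO)OC2=O)cc1` differs from compound 3 by hydroxymethyl in place of hydrogen on a saturated ring carbon. For the measured compounds named here, since compound 3 already sits at the limit, a move in the weaker direction cannot be seen, and a return to a finite number would require a large gain for which no precedent is present. The step from compound 3 to compound 4 is expected to be a number no higher from compound 3 to compound 4 (the limit leaves the size open), none beyond the scatter. For compound 4 the estimate in this assay is 40000 nM, with a range of 12000 nM to 120000 nM, most likely reported once more as a limit.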

Compound 4, half-maximal inhibitory concentration: > 40000 nM
Compound 4 gave a limit, no number; the forecaster's own chance of this, stated with the estimate: 85%; the middle value lies on the limit itself.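

Compound 3 and compound 4 both stand at a limit of the assay and not at a number, so no step between them can be read in this assay: the limit of > 40000 nM in this assay, at which 3 of the 4 values shown sit.

The compounds shown leave open what hydroxymethyl in place of hydrogen on a saturated ring carbon does to the read-out, and how far compound 3 and compound 4 lie from the limit.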